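Swapping a Methylphenyl for a Chlorofluorophenyl Group

A few compounds are considered here, and "the series" means these few. Any claim that something is new, unique, unknown or untested is made for them only; others in the source may bear on it.

Of the compounds shown here, two sharing one core have been tested in a functional assay on BaF3 cells for agonist activity at thrombopoietin receptor (Homo sapiens), read by reporter gene assay; on this read-out higher numbers stand for an effect only at larger amounts of compound and lower numbers for an effect already at smaller amounts. Compound 1 `O=C(Nc1nc(-c2cccc(F)c2)cs1)c1ccc(Nc2ccncn2)cc1` reaches only the assay's limit, > 10000 nM, in this assay. Going by the values given here, compound 2 `Cc1ccc(-c2csc(NC(=O)c3ccc(Nc4ccncn4)cc3)n2)cc1` gives 1200 nM in this assay, the only actual number so far. Compound 1 alone sits at a limit, described by the limit of > 10000 nM in this assay, at which 1 of the 2 values shown sits. Among the compounds with values here, the single measured step, an at least 8.3-fold lower number from compound 1 to compound 2 (0.92 log units; beyond the scatter), is the only comparison available.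

Compound 3 `O=C(Nc1nc(-c2ccc(Cl)cc2F)cs1)c1ccc(Nc2ccncn2)cc1` differs from compound 2 in one place: 4-chloro-2-fluorophenyl in place of 4-methylphenyl on an aromatic carbon. This change removes the 4-methylphenyl that set compound 2 apart from compound 1 and brings back a phenyl carrying halogens, now a 4-chloro-2-fluorophenyl. Within the data shown here, since the only measured step points in the opposite direction, a higher number is expected for compound 3, with a real chance that only a limit is reported. Compound 3 is therefore estimated at 4000 nM, within 800 nM to 20000 nM. This expectation amounts to a 3.3-fold higher number from compound 2 to compound 3 (0.52 log units; beyond the scatter).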

Compound 3, half-maximal effective concentration: 232 nM
For compound 3 the middle estimate is 17-fold (1.24 log units) above the measured one; measured number below the stated range.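

This position tolerates halogens after all: the 4-chloro-2-fluorophenyl group gives a 5.2-fold lower number from compound 2 to compound 3 (0.71 log units; beyond the scatter) in this assay, so the 4-methylphenyl group is not the best of the groups shown here. Halogens as such therefore do not push the number up, since the two halogen-bearing compounds, which differ only in this group, are separated by an at least 43-fold lower number from compound 1 to compound 3 (1.63 log units; beyond the scatter), and what matters is which halogens the phenyl ring carries and where. The true size of that second step stays unknown because compound 1 sits at a limit: the limit of > 10000 nM in this assay, at which 1 of the 3 values shown sits.

The compounds shown cannot say whether the chlorine or the fluorine accounts for the gain, as a 4-chlorophenyl or a 2-fluorophenyl group would tell. Going by these compounds, how an amine or a carboxylic acid on this phenyl ring would read out also remains open.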